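Widening the Amine on Compound 3: What Is Expected

This account rests on a few compounds, and the source may have more. Where it says the series, first, only, none or still open, it means among the compounds named here.

Measured compounds:
compound 1 `CCC(=O)N1N=C(C)CC1c1cc(Br)ccc1O`: in a functional assay on HepG2 cells (Homo sapiens) for cytotoxicity, read by MTT assay, with a stated time of 48 h (a higher number here means a weaker inhibitor, a lower number a stronger inhibitor), compound 1 gives "not active" (no number reported)
compound 2 `CCN(CC)CC(=O)N1N=C(C)CC1c1ccccc1O`: in this assay compound 2 gives 51600 nM
compound 3 `CNCC(=O)N1N=C(c2cc3ccccc3oc2=O)CC1c1ccccc1`: in this assay compound 3 gives 24000 nM

Going by the values given here, only two numbers exist, and compound 3 holds the lower of them. The gap from compound 3 up to compound 2 lies beyond the usual scatter, so compound 3 is, on these numbers, the stronger of the two. Compound 1 adds nothing to this ordering, since it was reported only as not active. Among the compounds with values here, no pair of measured compounds differs in a single place, so no measured step is available to lean on.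

Compound 4 `CC1CC(C)CN(CC(=O)N2N=C(c3cc4ccccc4oc3=O)CC2c2ccccc2)C1` is the next compound to be tested in this assay. It is derived from compound 3 by one change: 3,5-dimethylpiperidin-1-yl in place of methylamino on a saturated chain carbon bound to a carbonyl carbon. With no measured step of this kind in hand, the size of the effect can only be guessed. The expectation is a modest move toward a lower number, by about a 1.6-fold lower number from compound 3 to compound 4 (0.20 log units; within the scatter), and well within a range that also allows no change beyond the scatter. Compound 4 is therefore estimated at 15000 nM, between 5000 nM and 45000 nM.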

Compound 4, half-maximal inhibitory concentration: "not active" (no number reported)
Compound 4 has no reported number here, and the estimate cannot be compared.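

In this assay, going by these compounds alone, compound 4 gives "not active" (no number reported) and so no step from compound 3 to compound 4 can be read. No measured evidence bears on this result. The compounds shown leave open how far 3,5-dimethylpiperidin-1-yl, or any other group in place of methylamino, would move the number of compound 3.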